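The source may report more compounds than this note shows. Statements on the series, on what has been measured and on what is new or still open speak of the compounds shown alone.

Of the compounds shown here, three built on one shared core have been tested in a functional assay on SK-OV-3 cells (Homo sapiens) for antiproliferative activity, read by MTT assay, with a stated time of 24 h; a higher number here means a weaker inhibitor, a lower number a stronger inhibitor. Compound 1 `COc1ccc(C(=O)/C=C/c2cccc(F)c2)c2c1C=CC(C)(C)O2` reaches only the limit of this assay, > 10000 nM. Compound 2 `COc1ccc(C(=O)/C=C/c2cccc([N+](=O)[O-])c2)c2c1C=CC(C)(C)O2` gives 9720 nM in this assay. Compound 3 `COc1ccc(C(=O)/C=C/c2ccco2)c2c1C=CC(C)(C)O2` likewise stops at the limit of this assay, > 10000 nM. The step from compound 2 to compound 3 was an at least 1.0-fold higher number from compound 2 to compound 3 (0.01 log units; that floor lies within the scatter), and the step from compound 1 to compound 3 was a step that the two limits leave unreadable from compound 1 to compound 3 because two of the three values sit at the limit of > 10000 nM in this assay, at which 2 of the 3 values shown sit. Compound 4 `COc1ccc(C(=O)/C=C/c2cccc(O)c2)c2c1C=CC(C)(C)O2` differs from compound 3 by 3-hydroxyphenyl in place of furan-2-yl on a double-bonded chain carbon bound to a double-bonded chain carbon. Since the two exchanges on this chain carbon moved nothing readable, no shift beyond the scatter is expected in this assay: compound 4 is estimated at 10000 nM, between 4000 nM and 25000 nM, a step of a number no higher from compound 3 to compound 4 (the limit leaves the size open).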

Compound 4, half-maximal inhibitory concentration: > 10000 nM
Compound 4 ended at the assay's limit; the forecaster's own chance of this, stated with the estimate: 55%; the middle value sits exactly at the limit.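

In this assay, among the compounds shown here, 3-hydroxyphenyl brings a hydrogen-bond donor to this chain carbon, yet compound 4 shows no readable gain over the earlier compounds. Hydroxy in place of nitro gives an at least 1.0-fold higher number from compound 2 to compound 4 (0.01 log units; that floor lies within the scatter), so this change shows no shift beyond the scatter. The steps to compound 4 from compound 1 and from compound 3 cannot be read, because all three compounds sit at one limit, which is not a number: the limit of > 10000 nM in this assay, at which 3 of the 4 values shown sit.

As far as these compounds go, how these three compounds rank against one another stays open. So does whether an amine or a carboxylic acid on the aromatic ring would give a clearly measurable value.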